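A bicyclic arylidene in place of the hydroxyphenyl group

The compounds below may be only part of what the source reports. "The series", "measured", "known", "first", "only" and "open" are said of these compounds alone.

compound 1 `CCOC(=O)C1=C(Nc2ccccc2)S/C(=C\c2ccccc2O)C1=O`: 8800 nM
compound 2 `CCOC(=O)C1=C(Nc2ccccc2Br)S/C(=C\c2ccc[nH]2)C1=O`: 36300 nM
compound 3 `CCOC(=O)C1=C(Nc2ccc(F)cc2)S/C(=C\c2ccc[nH]2)C1=O`: > 100000 nM

In a functional assay on K562 cells (Homo sapiens) for inhibition, read by MTT assay, with a stated time of 72 h (on this read-out lower numbers stand for stronger inhibition and higher numbers for weaker inhibition), compound 1 gives 8800 nM, the lower of the two numbers measured, while compound 2 gives 36300 nM. For compound 3 this assay reports only a limit, > 100000 nM (the limit of > 100000 nM in this assay, at which 1 of the 3 values shown sits). Compound 4 `CCOC(=O)C1=C(Nc2ccccc2)S/C(=C\c2cc3ncccc3[nH]2)C1=O` differs from compound 1 by a group of 9 heavy atoms (7 carbon, 2 nitrogen; one five-membered aromatic ring with 1 hetero atom, one six-membered aromatic ring with 1 hetero atom) in place of a group of 7 heavy atoms (6 carbon, 1 oxygen; one six-membered aromatic ring of carbon only), on a double-bonded chain carbon bound to a double-bonded ring carbon. Going by the values given here, the single measured step, an at least 2.7-fold higher number from compound 2 to compound 3 (0.44 log units; beyond the scatter), concerns the amine nitrogen rather than the arylidene carbon, so no measured step bears directly on this change. Compounds 2 and 3 carry a five-membered ring at that carbon, and compound 2 sits above compound 1, but both also differ at the amine. A modest rise in the number is therefore expected, a 1.7-fold higher number from compound 1 to compound 4 (0.23 log units; within the scatter). Compound 4 is estimated at 15000 nM, between 4000 nM and 60000 nM.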

Compound 4, half-maximal inhibitory concentration: 6600 nM
Beside the measured number, compound 4's estimate is 2.3-fold (0.36 log units) above it; the measured number falls inside the stated range.
By their numbers in this assay, from the lowest: compounds 4 and 1 (each within the scatter of the next); then compound 2. At a limit, above all of these: compound 3.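

With the phenyl on the amine nitrogen held constant, the 2-hydroxyphenyl group on the double-bonded chain carbon gives way to a larger group carrying a five-membered and a six-membered aromatic ring, and this assay shows a 1.3-fold lower number from compound 1 to compound 4 (0.12 log units; within the scatter), so the two compounds cannot be told apart. At this position, the 2-hydroxyphenyl group is therefore not required to keep the number at this level, though nothing shown here accounts for the result. Still open, on these data alone, is whether an amine or a carboxylic acid on the entering group would shift the number. Also open, as far as these compounds go, is how that group would read alongside 2-bromophenyl or 4-fluorophenyl on the amine nitrogen.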